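Working notes: amide-to-anilide exchange on the piperazine carbonyl

A few compounds are considered here, and "the series" means these few. Any claim that something is new, unique, unknown or untested is made for them only; others in the source may bear on it.

Three compounds of the series have a number or a limit in a functional assay on cells (Lymphocyte); on this read-out lower numbers stand for stronger inhibition and higher numbers for weaker inhibition. Compound 3 `Nc1nc(N2CCN(C(=O)COc3ccccc3)CC2)c2ccsc2n1` gives 780 nM and stands lowest of the two numbers shown. Compound 1 `CCCCc1nc(N2CCN(C(=O)COc3ccc(Cl)cc3)CC2)c2cc(F)sc2n1` gives 1330 nM in this assay, a difference from compound 3 that lies within the scatter. Compound 2 `Nc1nc(N2CCN(C(=O)c3cccnc3)CC2)c2cc(F)sc2n1` is recorded only as a limit in this assay, > 10000 nM, and so supplies no number; it sits at the limit of > 10000 nM in this assay, at which 1 of the 3 values shown sits. 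

Compound 4 `Cc1cccc(NC(=O)N2CCN(c3nc(N)nc4sccc34)CC2)c1` has not been measured in this assay. Relative to compound 3 it carries (3-methylphenyl)amino in place of phenoxymethyl on a carbonyl carbon. Among the compounds with values here, no measured pair in the set makes this exchange, so its effect is not known from the data. A step of modest size toward a higher number, or none beyond the scatter, is the expectation for the move from compound 3, with wide uncertainty on either side. Compound 4 is thus expected to give about 1500 nM in this assay, plausibly between 400 nM and 6000 nM, which would correspond to an expected step of a 1.9-fold higher number from compound 3 to compound 4 (0.28 log units; within the scatter).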

Compound 4, half-maximal inhibitory concentration: 930 nM
Compound 4: the middle estimate sits 1.6-fold (0.21 log units) above what was measured, and the stated range covers the measured number.
By their numbers in this assay, from the lowest: compounds 3, 4 and 1 (each within the scatter of the next). At a limit, above all of these: compound 2.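

The exchange of phenoxymethyl for (3-methylphenyl)amino on the carbonyl carbon gives a 1.2-fold higher number from compound 3 to compound 4 (0.08 log units; within the scatter) in this assay, and this is the only comparison among the compounds shown that differs in one place. At this position, the read-out therefore does not separate the two groups, even though the entering group carries a hydrogen-bond donor and lacks the hydrogen-bond acceptor of the leaving group. Nothing measured in this set gives a reason for this result.

One exchange cannot show whether the same holds for other groups on this carbonyl carbon, nor what the methyl on the ring contributes. A plain phenylamino, a benzylamino with its longer chain, or a ring carrying a carboxylic acid would test how far this result extends.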